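Two methyl groups in place of a nitrile on the outer ring

The source may hold more compounds than are shown below. What is called first, only, known or untested is meant among the compounds shown, and "the series" means these compounds.

Measured so far in an assay on lysate for inhibition of phosphatidylcholine:ceramide cholinephosphotransferase 2 (Homo sapiens), read by HPLC, with stated times of 30 min and 2 h; on this read-out lower numbers stand for stronger inhibition and higher numbers for weaker inhibition:
compound 1 `O=C(NCc1ccco1)c1ccccc1OCc1ccccc1` gives 49000 nM
compound 2 `O=C(NC1CCCCC1)c1ccccc1OCc1ccccc1` gives 43400 nM
compound 3 `N#Cc1ccccc1COc1ccccc1C(=O)Nc1cccnc1` gives 31800 nM

Compound 3 has the lowest number of the three, yet its gaps to compound 2 and compound 1 both lie within the scatter, so the three cannot be ordered. Compound 4 `Cc1cccc(C)c1COc1ccccc1C(=O)Nc1cccnc1` differs from compound 3 by 2,6-dimethylphenyl in place of 2-cyanophenyl on a saturated chain carbon bound to an oxygen on an aromatic ring. Among the compounds with values here, the only measured step, a 1.1-fold lower number from compound 1 to compound 2 (0.05 log units; within the scatter), changes the group on the amide nitrogen and so does not touch the part altered here; nothing measured bears on this change. With no guidance, no step beyond the scatter is expected in this assay. Compound 4 is therefore estimated at 30000 nM (range 12000 nM to 75000 nM), an expected step of a 1.1-fold lower number from compound 3 to compound 4 (0.03 log units; within the scatter).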

Compound 4, half-maximal inhibitory concentration: 890 nM
Compound 4: middle estimate off by 34-fold (1.53 log units), on the high side, and the stated range ends above it.
By their numbers in this assay, from the lowest: compound 4; then compounds 3, 2 and 1 (each within the scatter of the next).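

In this assay, within the data shown here, the group on the saturated chain carbon bound to an oxygen on an aromatic ring matters far more than the earlier compounds could show: 2,6-dimethylphenyl in place of 2-cyanophenyl gives a 36-fold lower number from compound 3 to compound 4 (1.55 log units; beyond the scatter), the first step beyond the scatter. The change swaps the nitrile, with its hydrogen-bond acceptor, for two methyl groups, while the heavy-atom count stays the same. No measurement available explains why the number drops so far.

Still open, as far as these compounds go, is whether one methyl group alone would do as well, or two chlorine atoms in place of the two methyl groups. Also open, from the compounds shown here alone, is whether 2,6-dimethylphenyl gives a similar step with cyclohexyl on the amide nitrogen.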